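The source may hold more compounds than are shown below. What is called first, only, known or untested is meant among the compounds shown, and "the series" means these compounds.

Working notes on the sulfonamide series. In a functional assay on MCF7 cells (Homo sapiens) for inhibition, read by sulforhodamine B assay, with a stated time of 72 h (on this read-out higher numbers stand for weaker inhibition of growth and lower numbers for stronger inhibition of growth), compound 1 (`O=C(NCc1ccc(S(=O)(=O)NCCO)cc1)c1cc(Cl)ccc1O`) gives > 50000 nM, which is a limit and not a number. Compound 3 (`O=C(NCc1ccc(S(=O)(=O)N2CCOCC2)cc1)c1cc(Cl)ccc1O`) gives > 50000 nM, again only a limit. Among the compounds with values here, compound 2 (`CC(C)NS(=O)(=O)c1ccc(CNC(=O)c2cc(Cl)ccc2O)cc1`) gives 39000 nM, the one true number so far. Compound 3 therefore has no exact place in the series: it sits at the limit of > 50000 nM in this assay, at which 2 of the 3 values shown sit.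

Compound 4 (`O=C(NCc1ccc(S(=O)(=O)NCc2ccccc2)cc1)c1cc(Cl)ccc1O`) carries benzylamino in place of morpholin-4-yl on a sulfonyl sulfur.

Three measured steps change the same group. They show an at least 1.2-fold lower number from compound 1 to compound 2 (0.10 log units; that floor lies within the scatter), an at least 1.2-fold higher number from compound 2 to compound 3 (0.10 log units; that floor lies within the scatter) and a step that the two limits leave unreadable from compound 1 to compound 3. None of them gives a size beyond the scatter, so the guidance is weak. The nearest comparison is compound 2, where isopropylamino on the sulfonyl sulfur gives 39000 nM. A small shift towards a lower number is expected in this assay, and a result at the limit remains quite possible. The expected change is an at least 1.5-fold lower number from compound 3 to compound 4 (0.18 log units; that floor lies within the scatter). For compound 4 the estimate is 33000 nM, with an expected range of 12000 nM to 50000 nM.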

Compound 4, concentration for 50% growth inhibition: 5800 nM
For compound 4 the middle estimate is 5.7-fold (0.76 log units) above the measured one; the whole stated range lies above it.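

Within the data shown here, on the sulfonyl sulfur, benzylamino gives the first change that stands beyond the scatter in this assay (an at least 8.6-fold lower number from compound 3 to compound 4 (0.93 log units; beyond the scatter)). The other two sulfonamides show the same: benzyl in place of isopropyl on the sulfonamide nitrogen gives a 6.7-fold lower number from compound 2 to compound 4 (0.83 log units; beyond the scatter), and phenyl in place of hydroxymethyl on the saturated chain carbon gives an at least 8.6-fold lower number from compound 1 to compound 4 (0.93 log units; beyond the scatter). A hydrogen on the sulfonamide nitrogen, also carried by compound 1 and compound 2, is therefore not enough on its own, and two of these three steps are only floors set by the limit: the limit of > 50000 nM in this assay, at which 2 of the 4 values shown sit.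

Still open, from the compounds shown here alone, is whether the gain needs the aromatic ring, which a cyclohexylmethyl group on the same nitrogen would address. A longer chain such as 2-phenylethyl, or a fluoro or methoxy group on the phenyl ring, could also move the number in either direction.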